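The source may hold more compounds than are shown below. What is called first, only, known or untested is meant among the compounds shown, and "the series" means these compounds.

Compound 1 `CC(C)CCn1ccc(N2CCC(c3ccccc3)CC2)c(C#N)c1=O`: 268%
Compound 2 `CC(C)CCn1ccc(N2CCCC(c3ccccc3)C2)c(C#N)c1=O`: 231%
Compound 3 `CC(C)CCn1ccc(N2CCCCC2)c(C#N)c1=O`: 185%

These three compounds share one core and were tested in a functional assay on CHO cells for positive allosteric modulation of metabotropic glutamate receptor 2 (Homo sapiens), with a stated time of 30 min; a lower number here means a smaller maximal response, a higher number a larger maximal response. Compound 1 stands highest of the three; compound 2 gives a lower number, and compound 3 lower still. The two recorded steps, a number 83 percentage points lower from compound 1 to compound 3 (beyond the scatter) and a number 46 percentage points lower from compound 2 to compound 3 (beyond the scatter), both concern the phenyl on the saturated ring. Compound 4 `CCCCn1ccc(N2CCC(c3ccccc3)CC2)c(C#N)c1=O` keeps that phenyl and differs from compound 1 elsewhere: hydrogen in place of methyl on a saturated chain carbon bound to two saturated chain carbons. Going by the values given here, no measured step touches this part of the molecule, so there is nothing to point to a change in either direction. The expectation for compound 4 is therefore a step of a number 13 percentage points lower from compound 1 to compound 4 (beyond the scatter), within the scatter. Compound 4 is estimated at 255%, with a range from 200% to 300%.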

Compound 4, largest response reached (Emax), in percent of the reference or control that the assay uses: 309%
Compound 4: the middle estimate sits 54 percentage points below what was measured; measured number outside the range, above it.
By their numbers in this assay, from the lowest: compound 3; then compound 2; then compound 1; then compound 4.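

The chain on the nitrogen of the shared core turns out to matter: going from isopentyl to butyl gives a number 41 percentage points higher from compound 1 to compound 4 (beyond the scatter) in this assay, a clear change from one methyl leaving. In this pair, then, the branching methyl is not needed for a large maximal response, and the unbranched chain does better. Nothing measured here explains this rise.

From the compounds shown here alone, whether propyl, pentyl or a chain ending in an amine or a carboxylic acid would raise the response further remains open. So does whether butyl would give a similar step in compound 2 or compound 3.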